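A few compounds are considered here, and "the series" means these few. Any claim that something is new, unique, unknown or untested is made for them only; others in the source may bear on it.

Compound 1 `NC(=O)[C@@H](CCC(F)(F)F)N(CC1COC1)S(=O)(=O)c1ccc(Cl)cc1` gives 16.9 mL/min/kg in an in vitro ADME assay on microsomes from liver (Homo sapiens) for metabolic stability, read by HPLC; on this read-out lower numbers stand for slow clearance and higher numbers for fast clearance. Compound 2 `NC(=O)[C@@H](CCC(F)(F)F)N(C[C@H]1CCCCO1)S(=O)(=O)c1ccc(Cl)cc1` reaches only a limit in this assay, > 300 mL/min/kg, which is a limit and not a number. Compound 3 `NC(=O)[C@@H](CCC(F)(F)F)N(C[C@@H]1CCCOC1)S(=O)(=O)c1ccc(Cl)cc1` gives 136 mL/min/kg in this assay.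

Among the two definite numbers compound 3 stands highest, with compound 1 nearest at an 8.0-fold higher number from compound 1 to compound 3 (0.91 log units; beyond the scatter). The step of an at least 2.2-fold lower number from compound 2 to compound 3 (0.34 log units; beyond the scatter) is read against the limit (the limit of > 300 mL/min/kg in this assay, at which 1 of the 3 values shown sits). Compound 4 `NC(=O)[C@@H](CCC(F)(F)F)N(C[C@@H]1COCCO1)S(=O)(=O)c1ccc(Cl)cc1` carries 1,4-dioxan-2-yl in place of oxan-3-yl on a saturated chain carbon bound to a sulfonamide nitrogen. The earlier ring swaps bear on this: an at least 17-fold higher number from compound 1 to compound 2 (1.24 log units; beyond the scatter) and an 8.0-fold higher number from compound 1 to compound 3 (0.91 log units; beyond the scatter) both moved toward faster clearance, while an at least 2.2-fold lower number from compound 2 to compound 3 (0.34 log units; beyond the scatter) moved the other way. Exchanging one six-membered ring for another resembles that last step more than the first two, so only a small move is expected, a 1.5-fold lower number from compound 3 to compound 4 (0.18 log units; within the scatter) in this assay. The estimate for compound 4 is 90 mL/min/kg, within 40 mL/min/kg to 220 mL/min/kg.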

Compound 4, clearance: 117 mL/min/kg
For compound 4 the middle estimate is 1.3-fold (0.11 log units) below the measured one; the range from low to high includes it.
By their numbers in this assay, from the lowest: compound 1; then compounds 4 and 3 (each within the scatter of the next). At a limit, above all of these: compound 2.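

Putting 1,4-dioxan-2-yl in place of oxan-3-yl gives a 1.2-fold lower number from compound 3 to compound 4 (0.07 log units; within the scatter) in this assay, so these two six-membered rings cannot be told apart here. Against oxetan-3-yl, the new ring still shows a 6.9-fold higher number from compound 1 to compound 4 (0.84 log units; beyond the scatter), leaving compound 1 clearly slower in clearance. The step of an at least 2.5-fold lower number from compound 2 to compound 4 (0.40 log units; beyond the scatter) rests on a limit and not a number: the limit of > 300 mL/min/kg in this assay, at which 1 of the 4 values shown sits.

From the compounds shown here alone, whether compound 1 owes its low number to ring size or to the oxetan-3-yl group itself stays open. A five-membered oxolan-3-yl ring or a cyclobutyl ring without oxygen at this place could help separate the two.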